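Nitro for methoxy on the aryl ketone: expectation

The source may report more compounds than this note shows. Statements on the series, on what has been measured and on what is new or still open speak of the compounds shown alone.

Compound 3 `COc1ccc(C(=O)/C=C/c2ccc(OCc3cn(Cc4ccc(F)cc4)nn3)cc2)cc1` gives 21% in a functional assay on HepG2 cells (Homo sapiens) for inhibition, read by MTT assay, with a stated time of 48 h, tested at 10 uM (on this read-out higher numbers stand for more inhibition of growth at the one concentration tested and lower numbers for less inhibition of growth), the lowest of the three numbers, though compound 2 `COc1ccc(C(=O)/C=C/c2ccc(OCc3cn(Cc4cccc(F)c4)nn3)cc2)cc1` gives 22% and the step of a number 1 percentage points lower from compound 2 to compound 3 (within the scatter) lies within the scatter. Compound 1 `COc1ccc(C(=O)/C=C/c2ccc(OCc3cn(Cc4ccccc4Br)nn3)cc2)cc1` gives 44%; the steps of a number 22 percentage points lower from compound 1 to compound 2 (beyond the scatter) and a number 23 percentage points lower from compound 1 to compound 3 (beyond the scatter) lie beyond it. Compound 4 `O=C(/C=C/c1ccc(OCc2cn(Cc3ccc(F)cc3)nn2)cc1)c1ccc([N+](=O)[O-])cc1` differs from compound 3 by nitro in place of methoxy on an aromatic carbon, on an aromatic carbon of a six-membered aromatic ring of carbon only, para to a large group. Among the measured compounds shown here, every measured step changes the aryl group on the saturated chain carbon bound to an aromatic nitrogen; none touches this place, so no measured step bears on it. With nothing to go on, no step beyond the scatter is expected in this assay, and compound 4 is estimated at 25% (range 5% to 55%), an expected step of a number 4 percentage points higher from compound 3 to compound 4 (within the scatter) with a wide range.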

Compound 4, percent growth inhibition at one concentration: 25%
Compound 4: the middle estimate sits on the measured number at the digits printed, within the range that was stated.
By their numbers in this assay, from the lowest: compounds 3, 2 and 4 (each within the scatter of the next); then compound 1.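

In this assay, replacing 4-methoxyphenyl with 4-nitrophenyl on the ketone gives a number 4 percentage points higher from compound 3 to compound 4 (within the scatter), the one change shown at this place. In this single pair, nitro in place of methoxy on this aromatic carbon produces no step beyond the scatter, whereas the steps beyond it so far come from changing the aryl group on the saturated chain carbon, from compound 1. No measured evidence bears on this result.

As far as these compounds go, whether nitro behaves the same way alongside the 2-bromophenyl group of compound 1 remains open. So does the effect of an amine or a carboxylic acid on this aromatic carbon.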